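Chloro for methoxy on the core of compound 1

The source may hold more compounds than are shown below. What is called first, only, known or untested is meant among the compounds shown, and "the series" means these compounds.

Compound 1 `COc1ccc2c(c1)c(C(=O)C(=O)Nc1ccc(OC)nc1)cn2C(C)C`: > 10000 nM
Compound 2 `CC(C)Oc1ccc(NC(=O)C(=O)c2cn(C(C)C)c3ccccc23)cn1`: 408 nM

In a functional assay on FaDu cells (Homo sapiens) for cytotoxicity, read by MTT assay, with a stated time of 72 h (on this read-out higher numbers stand for lower toxicity in this test and lower numbers for higher toxicity in this test), compound 1 stands at > 10000 nM, which is a limit of the assay and not a number. Compound 2, by contrast, gives a measured 408 nM. Compound 3 `COc1ccc(NC(=O)C(=O)c2cn(C(C)C)c3ccc(Cl)cc23)cn1`, not yet measured, differs from compound 1 in one place, with chloro in place of methoxy on an aromatic carbon. Going by the values given here, no measured step shows what this change does, so the expectation is tentative. A move towards lower numbers, meaning higher toxicity, is expected, and the estimated size is an at least 10-fold lower number from compound 1 to compound 3 (1.00 log units; beyond the scatter). For compound 3 the expected value is 1000 nM, with an estimated range from 150 nM to 8000 nM.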

Compound 3, concentration lethal to 50% of the cells: > 10000 nM
Compound 3: only a limit was reported; the forecaster's own chance of this, stated with the estimate: 15%; at least 10-fold (1.00 log units) between middle value and limit.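

Compound 1 and compound 3 both end at a limit of the assay and not a number, so no step between them can be read: the limit of > 10000 nM in this assay, at which 2 of the 3 values shown sit.

On these data alone, whether chloro in place of methoxy changes the toxicity in this test at all stays open.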